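Swapping the Charged Tail of a Collagen-Promoter Inhibitor

The compounds below may be only part of what the source reports. "The series", "measured", "known", "first", "only" and "open" are said of these compounds alone.

Compound 1, `Cc1cc(-n2cc(C(=O)Nc3cc(F)cc(F)c3)c(=O)c3ccc(N(C)C)nc32)ccc1OCCCCCCC[n+]1ccccc1`, was tested in an assay on LX2 cells for inhibition of COL1A1 promoter (Homo sapiens), read by a luciferase reporter, with a stated time of 24 h, tested at 50 uM (a lower number here means a weaker effect, a higher number a stronger effect of the compound at the concentration tested), where compound 1 gave 55%. Its closest relative, compound 2, `CN(C)c1ccc2c(=O)c(C(=O)Nc3cc(F)cc(F)c3)cn(-c3ccc(OCCCCCCC[n+]4ccccc4)c(Cl)c3)c2n1`, gave 21.4% in the same test. The two structures differ only by a chloro in place of methyl on an aromatic carbon, and the step was a number 33.6 percentage points lower from compound 1 to compound 2 (beyond the scatter). Going by the values given here, compound 1 therefore stands highest of the two numbers measured so far, with compound 2 well below it.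

Compound 3, `CC[N+]1(CCCCCCCOc2ccc(-n3cc(C(=O)Nc4cc(F)cc(F)c4)c(=O)c4ccc(N(C)C)nc43)cc2C)CCCC1`, has not yet been measured. It keeps the methyl of compound 1 and instead changes the far end of the chain: a group of 7 heavy atoms (6 carbon, 1 nitrogen; one five-membered non-aromatic ring with 1 hetero atom) in place of a group of 6 heavy atoms (5 carbon, 1 nitrogen; one six-membered aromatic ring with 1 hetero atom), on a saturated chain carbon, seven bonds along the chain from an oxygen on an aromatic ring. Among the compounds with values here, no measured step touches this part of the molecule; the only step known concerns a different position and says nothing about the charged end of the chain. With no evidence either way, the expected step from compound 1 to compound 3 is a number 5 percentage points lower from compound 1 to compound 3 (within the scatter), that is, none beyond the scatter, though the uncertainty is wide. Compound 3 is therefore estimated at 50%, within a range from 25% to 75%.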

Compound 3, a percentage reported as inhibition, at one concentration (the size of the read-out at that concentration, not a potency): 82.5%
The estimate for compound 3 lay 32.5 percentage points below the measured number; measured number outside the range, above it.
By their numbers in this assay, from the lowest: compound 2; then compound 1; then compound 3.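

The charged end of the chain is a place where the read-out can change strongly: in this assay, replacing the six-membered aromatic ring with 1 hetero atom by the group holding a five-membered non-aromatic ring with 1 hetero atom gives a number 27.5 percentage points higher from compound 1 to compound 3 (beyond the scatter). Both groups have a net charge of +1 and 0 hydrogen-bond donors and acceptors, so these shared counts do not settle the result, and two separate single changes to compound 1 have now moved the number, one downward with chloro and one upward at the chain end. Nothing available here bears on the reason for this rise.

The entering group differs from the leaving one in ring size, in being non-aromatic and in its heavy-atom count, so a piperidinium ring or a trimethylammonium group at the same place would help to separate these features. A longer chain bearing the same charged group, or a compound combining that group with chloro in place of methyl, would show whether this gain persists when another part of the molecule changes, and each number here still describes one concentration rather than a potency.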